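Para-Substituted Benzylpurines: A Second Chloro Enters

The source may hold more compounds than are shown below. What is called first, only, known or untested is meant among the compounds shown, and "the series" means these compounds.

The series rests on a purine core carrying a chloromethyl-substituted benzyl group, and its growth-inhibiting activity was followed in a functional assay on MOLT-4 cells (Homo sapiens) for cytotoxicity, read by sulforhodamine B assay, with a stated time of 48 h; a lower number here means a stronger inhibitor of growth, a higher number a weaker inhibitor of growth. Compound 1 `Nc1nc(Cl)c2ncn(Cc3ccccc3CCl)c2n1` carries an amino group on the core, and in this assay compound 1 gives only a limit of the assay, > 100000 nM, the point at which (the limit of > 100000 nM in this assay, at which 1 of the 3 values shown sits). Compound 2 `ClCc1ccccc1Cn1cnc2ncnc(Cl)c21`, with the chloromethyl group on the adjacent benzyl position and no amino group, gives 4260 nM in this assay. Compound 3 `ClCc1ccc(Cn2cnc3ncnc(Cl)c32)cc1` moves the chloromethyl group to the para position of the benzyl ring; for compound 3 the entry in this assay reads "not determined" (no result reported), so it stands without a number among the values shown. Compound 4 `ClCc1ccc(Cn2cnc3nc(Cl)nc(Cl)c32)cc1` keeps that benzyl group and differs from compound 3 in one place: chloro in place of hydrogen on an aromatic carbon. Among the compounds with values here, no measured step in this set covers such a change, so the size of the step can only be guessed. Given that compound 2 gives 4260 nM in this assay, a value of the same order is expected for the para-substituted pair, with the added chloro neither clearly raising nor lowering it beyond the scatter. Compound 4 is therefore expected to give about 3500 nM, within a range of 800 nM to 15000 nM, in this assay.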

Compound 4, concentration for total growth inhibition: 5490 nM
Beside the measured number, compound 4's estimate is 1.6-fold (0.20 log units) below it, and the stated range covers the measured number.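

In this assay, within the data shown here, compound 3 stands without a number, so no step from compound 3 to compound 4 can be read. The compounds shown leave open what chloro in place of hydrogen on the shared core does to growth inhibition, and nothing shown bears on the value of compound 4.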